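A Longer Chain on the Charged Nitrogen of Compound 3

The compounds below may be only part of what the source reports. "The series", "measured", "known", "first", "only" and "open" are said of these compounds alone.

Of the compounds shown here, three that share one core have been measured in a physicochemical assay for solubility; a lower number here means a less soluble compound, a higher number a more soluble compound. Compound 1 `COc1cc2cc(C(=O)CCC3CC[N+](C)(Cc4ccccc4)CC3)sc2cc1OC` gives 2000 ug/mL in this assay. Compound 2 `COc1cc2cc(C=C3CC[N+](C)(Cc4ccccc4)CC3)sc2cc1OC` gives 1000 ug/mL. Compound 3 `COc1cc2cc(C(=O)CCc3cc[n+](C)cc3)sc2cc1OC` gives 3000 ug/mL, the highest of the three numbers, although its gap to compound 1 falls within the usual scatter, while its gap to compound 2 lies beyond it. Compound 4 `C=CC[n+]1ccc(CCC(=O)c2cc3cc(OC)c(OC)cc3s2)cc1` is not yet measured; it differs from compound 3 by vinyl in place of hydrogen on a saturated chain carbon bound to an aromatic nitrogen, so that a methyl becomes an allyl. Among the measured compounds shown here, no step between measured compounds of this kind is available, so the step expected in this assay is a 1.5-fold lower number from compound 3 to compound 4 (0.18 log units; within the scatter), a modest decrease that may well stay within the scatter. Compound 4 is therefore estimated at 2000 ug/mL, with a plausible range from 900 ug/mL to 4000 ug/mL.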

Compound 4, solubility: 25000 ug/mL
Beside the measured number, compound 4's estimate is 13-fold (1.10 log units) below it; the whole stated range lies below it.
By their numbers in this assay, from the lowest: compounds 2, 1 and 3 (each within the scatter of the next, the first and the last beyond it); then compound 4.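

On a saturated chain carbon bound to an aromatic nitrogen, a small change can carry a large effect: in this assay, vinyl in place of hydrogen, which turns a methyl into an allyl, gives an 8.3-fold higher number from compound 3 to compound 4 (0.92 log units; beyond the scatter). Among the compounds shown here, this is the first step at this position that can be read, and it lies beyond the scatter. Nothing measured here explains the rise. From the compounds shown here alone, whether it depends on the double bond or on chain length alone remains open. A saturated propyl chain or a benzyl group in the same place would test this.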